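The source may report more compounds than this note shows. Statements on the series, on what has been measured and on what is new or still open speak of the compounds shown alone.

Measured so far in an assay on isolated protein (strain Sprague-Dawley) for inhibition of Amine oxidase [flavin-containing] A (Rattus norvegicus), read by spectrophotometry, with a stated time of 5 min, tested at 10 uM; a higher number here means more inhibition at the concentration tested (going by the name of the read-out), a lower number less inhibition:

compound 1, `CCCOc1cc(=O)oc2cc(OCc3ccccc3)ccc12` — 0%
compound 2, `CCOC(=O)COc1cc(=O)oc2cc(OCc3cccc(Cl)c3)ccc12` — 0%

Compound 2 stands level with compound 1 in this assay at the digits given: the two values lie within the scatter of each other, so nothing here separates them, and neither shows measurable inhibition at the test concentration. Among the measured compounds shown here, no step between measured compounds is available. The two share no single point of difference.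

Compound 3, `O=c1cc(Nc2ccccc2)c2ccc(OCc3cccc(Cl)c3)cc2o1`, remains to be measured in this assay. Against compound 2 the change is anilino in place of (ethoxycarbonyl)methoxy on an aromatic carbon. For the measured compounds named here, this is the only change; the remainder of the shared core is kept as in compound 2.

Expectation: with both compound 1 and compound 2 giving no inhibition, the series so far offers no measured step on which to base a shift. The step of a number 10 percentage points higher from compound 2 to compound 3 (within the scatter) is expected to be small and upward at most, possibly none beyond the scatter. Compound 3 is therefore estimated at 10%, with a range from 0% to 35%.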

Compound 3, a percentage reported as inhibition, at one concentration (the size of the read-out at that concentration, not a potency): 0%
Estimate against measurement, compound 3: 10 percentage points above; measured number inside the range.
By their numbers in this assay, from the lowest: compounds 1, 2 and 3 (each within the scatter of the next).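

Putting anilino in place of (ethoxycarbonyl)methoxy, on the aromatic carbon opposite the ring oxygen, gives no change at the digits printed from compound 2 to compound 3 (within the scatter) in this assay. Among the compounds shown here, this is the first single-place comparison, and it exchanges a group with no ring and no hydrogen-bond donor for one with a six-membered aromatic ring of carbon only and a hydrogen-bond donor, yet compound 3 stands at 0%, so neither group gives measurable inhibition at the concentration tested, and the two cannot be ranked at this position. Nothing measured here offers an explanation for this result.

From the compounds shown here alone, whether a carboxylic acid, a morpholine ring or a longer alkoxy chain on this aromatic carbon would lift inhibition beyond the scatter remains open. Compound 1 and compound 2 differ in more than one place, so the separate contribution of each change between them also remains unread.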